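Notes on the acyl variations in this spiro series

A few compounds are considered here, and "the series" means these few. Any claim that something is new, unique, unknown or untested is made for them only; others in the source may bear on it.

Measured so far in an assay on HEK293 cells for displacement of a labelled ligand from NPC1-like intracellular cholesterol transporter 1 (Homo sapiens); a lower number here means a stronger inhibitor, a higher number a weaker inhibitor:
compound 1 `CC(C)(C)c1ccc(C(=O)N2CCC3(CC2)C(=O)N(CC(=O)N2CCC(CCO)CC2)CN3c2ccccc2)cc1`: 2600 nM
compound 2 `CC(C)(C)OC(=O)NCCNC(=O)CN1CN(c2ccccc2)C2(CCN(C(=O)c3ccc(C(C)(C)C)cc3)CC2)C1=O`: 10900 nM
compound 3 `CC1(C)CC(OC(=O)CN2CN(c3ccccc3)C3(CCN(C(=O)c4ccc(C(C)(C)C)cc4)CC3)C2=O)CC(C)(C)N1`: 1300 nM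

Compound 3 gives the lowest of the three numbers, though the step of a 2.0-fold lower number from compound 1 to compound 3 (0.30 log units; within the scatter) is within the scatter and thus not resolved, while an 8.4-fold lower number from compound 2 to compound 3 (0.92 log units; beyond the scatter) is clear. Compound 4 `CC(C)(C)c1ccc(C(=O)N2CCC3(CC2)C(=O)N(CC(=O)N2CCCCC2CO)CN3c2ccccc2)cc1` is not yet measured; it differs from compound 3 by 2-(hydroxymethyl)piperidin-1-yl in place of (2,2,6,6-tetramethylpiperidin-4-yl)oxy on a carbonyl carbon. Compound 4 therefore most resembles compound 1, which carries a piperidin-1-yl group bearing a hydroxyalkyl chain on the same carbonyl carbon. The step of a 2.0-fold lower number from compound 1 to compound 3 (0.30 log units; within the scatter) was within the scatter, so no step beyond the scatter is expected here either. For compound 4 the estimate in this assay is 2500 nM (range 1000 nM to 7000 nM), corresponding to an expected step of a 1.9-fold higher number from compound 3 to compound 4 (0.28 log units; within the scatter).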

Compound 4, half-maximal inhibitory concentration: 11800 nM
Compound 4: middle estimate off by 4.7-fold (0.67 log units), on the low side; the measured number lies above the stated range.
By their numbers in this assay, from the lowest: compounds 3 and 1 (each within the scatter of the next); then compounds 2 and 4 (each within the scatter of the next).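

In this assay, a piperidin-1-yl group bearing a hydroxyalkyl chain on this carbonyl carbon does not settle the number: a 4.5-fold higher number from compound 1 to compound 4 (0.66 log units; beyond the scatter) separates 2-(hydroxymethyl)piperidin-1-yl from 4-(2-hydroxyethyl)piperidin-1-yl. The entry of 2-(hydroxymethyl)piperidin-1-yl gives a 9.1-fold higher number from compound 3 to compound 4 (0.96 log units; beyond the scatter) against the (2,2,6,6-tetramethylpiperidin-4-yl)oxy group, while a 1.1-fold higher number from compound 2 to compound 4 (0.03 log units; within the scatter) leaves it unresolved from the (2-((tert-butoxycarbonyl)amino)ethyl)amino group. No measurement at hand accounts for these differences.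

Open, going by these compounds, is what unsubstituted piperidin-1-yl would give, without any hydroxyalkyl chain. Also open, on these data alone, is whether (2,2,6,6-tetramethylpiperidin-4-yl)amino would match the oxy-linked group of compound 3.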